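From Compound 2 to Its Benzyl Sulfonamide

The compounds below may be only part of what the source reports. "The series", "measured", "known", "first", "only" and "open" are said of these compounds alone.

Measured in a physicochemical assay for lipophilicity, at pH 7.4; a lower number here means a more polar compound, a higher number a more lipophilic compound:
Compound 1 `CCc1ccc(N(C2CCC2)S(=O)(=O)c2ccc3c(c2)C(O)CC(C2CCOCC2)O3)cc1`: 3.69
Compound 2 `CCc1ccc(NS(=O)(=O)c2ccc3c(c2)C(O)CC(C2CCOCC2)O3)cc1`: 2.59

Compound 2 holds the lower of the two numbers, at 2.59. Compound 3 `CCc1ccc(N(Cc2ccccc2)S(=O)(=O)c2ccc3c(c2)C(O)CC(C2CCOCC2)O3)cc1` remains unmeasured and carries one change: benzyl in place of hydrogen on a sulfonamide nitrogen. Going by the values given here, one measured step bears on this, with hydrogen in place of cyclobutyl on a sulfonamide nitrogen: a number 1.10 log units lower from compound 1 to compound 2 (beyond the scatter). That step is large and beyond the scatter. Run in reverse, it suggests a large rise in this assay. The expected change is a number 1.31 log units higher from compound 2 to compound 3 (beyond the scatter). Compound 3 is estimated at 3.9, with an expected range of 3.4 to 4.4.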

Compound 3, distribution coefficient: 4.68
Estimate against measurement, compound 3: 0.78 log units below; the whole stated range lies below it.
By their numbers in this assay, from the lowest: compound 2; then compound 1; then compound 3.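

At the sulfonamide nitrogen, this assay now separates one carbon substituent from another, and not only substituted from unsubstituted: benzyl in place of hydrogen gives a number 2.09 log units higher from compound 2 to compound 3 (beyond the scatter), and benzyl in place of cyclobutyl gives a number 0.99 log units higher from compound 1 to compound 3 (beyond the scatter). The size of the rise at this position therefore depends on the group that enters, and compound 3 stands highest of the three. No measurement given here explains the difference between benzyl and cyclobutyl.

Still open, from the compounds shown here alone, is whether an amine or a carboxylic acid carried on this nitrogen would bring the number back toward that of compound 2, and where a longer alkyl chain would stand.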